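Methoxy for hydrogen: a cytotoxicity estimate

This account rests on a few compounds, and the source may have more. Where it says the series, first, only, none or still open, it means among the compounds named here.

Three compounds on a shared core have numbers in a functional assay on A549 cells (Homo sapiens) for cytotoxicity, read by MTT assay, with a stated time of 48 h; a lower number here means a stronger inhibitor, a higher number a weaker inhibitor. Compound 1 `c1cc(-c2nc3ccccc3[nH]2)cc(-c2nc3ccccc3[nH]2)c1` gives 38500 nM in this assay. Compound 2 `FC(F)(F)c1ccc2nc(-c3cccc(-c4nc5ccc(C(F)(F)F)cc5[nH]4)c3)[nH]c2c1` gives 8900 nM in this assay, and compound 3 `Clc1ccc2nc(-c3cccc(-c4nc5ccc(Cl)cc5[nH]4)c3)[nH]c2c1` gives 23700 nM. Compound 2 stands lowest of the three; its gap to compound 3 and its gap to compound 1 both lie beyond the usual scatter, so compound 2 is the strongest inhibitor among the measured set.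

Compound 4 `COc1cc(-c2nc3ccc(C(F)(F)F)cc3[nH]2)cc(-c2nc3ccc(C(F)(F)F)cc3[nH]2)c1` has not yet been measured in this assay. It differs from compound 2 in one place: methoxy in place of hydrogen on an aromatic carbon. Both trifluoromethyl groups of compound 2 remain in compound 4. Within the data shown here, no pair among the measured compounds shows what this particular change does, so the size of the step is not known from the data. The expectation in this assay is a step of small size, quite possibly within the scatter, with only a slight lean towards a lower number. Compound 4 is therefore expected to give about 7000 nM in this assay, within a range from 2800 nM to 18000 nM. The estimated step is a 1.3-fold lower number from compound 2 to compound 4 (0.10 log units; within the scatter), which is expected to fall near the edge of the scatter.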

Compound 4, half-maximal inhibitory concentration: 8100 nM
Estimate against measurement, compound 4: 1.2-fold (0.06 log units) below; measured number inside the range.
By their numbers in this assay, from the lowest: compounds 4 and 2 (each within the scatter of the next); then compounds 3 and 1 (each within the scatter of the next).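

In this assay, the step for methoxy in place of hydrogen on an aromatic carbon, meta to two large groups, is a 1.1-fold lower number from compound 2 to compound 4 (0.04 log units; within the scatter), so compound 4 and compound 2 cannot be told apart on this read-out. Compound 1, compound 2 and compound 3 all carry hydrogen at this carbon and could not show how it responds to a substituent; with both trifluoromethyl groups in place, it now accepts methoxy, with its 2 heavy atoms and 1 hydrogen-bond acceptor, without a step beyond the scatter. Nothing in the available data speaks to a cause for this result.

Going by these compounds, whether this flat response extends to other groups at the same carbon, such as an amine, a carboxylic acid or a longer alkoxy chain, remains open. Also open is whether methoxy gives a similarly small step on the cores of compound 1 and compound 3, since the single step shown comes from the trifluoromethyl-bearing pair alone.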